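The compounds below may be only part of what the source reports. "The series", "measured", "known", "first", "only" and "open" are said of these compounds alone.

Measured in an ADME assay on microsomes from liver (Homo sapiens) for metabolic stability, read by LC-MS, using NADPH, tested at 10 uM; a higher number here means faster removal of the compound, a lower number slower removal:
- compound 1 `CCc1ccc(N(CC2CC2)S(=O)(=O)c2ccc3c(c2)C(=O)CC(C2CCOCC2)O3)cc1`: 55.8 mL/min/kg
- compound 2 `CCc1ccc(N(CC(C)C)S(=O)(=O)c2ccc3c(c2)C(=O)CC(C2CCOCC2)O3)cc1`: 288 mL/min/kg

Within the data shown here, of the two compounds measured so far, compound 2 stands highest, at 288 mL/min/kg. Its nearest neighbour is compound 1, at 55.8 mL/min/kg, and the gap between them lies beyond the usual scatter.

The next compound, compound 3 `CC(C)CN(c1ccc(N(C)C)cc1)S(=O)(=O)c1ccc2c(c1)C(=O)CC(C1CCOCC1)O2`, keeps everything in compound 2 except one group: dimethylamino in place of ethyl on an aromatic carbon, para to a large group (dimethylamino in place of ethyl on an aromatic carbon).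

Among the measured compounds shown here, only one measured step is available, a 5.2-fold higher number from compound 1 to compound 2 (0.71 log units; beyond the scatter). It came with isopropyl in place of cyclopropyl on a saturated chain carbon bound to a sulfonamide nitrogen, so it concerns a different place in the molecule and gives no direct measure of this exchange. For the measured compounds named here, no measured step covers ethyl and dimethylamino, so no step beyond the scatter is expected in this assay, and the direction remains open. The expectation therefore rests on compound 2 at 288 mL/min/kg, with a wide margin on either side.

The expected step is a 1.3-fold lower number from compound 2 to compound 3 (0.12 log units; within the scatter).

For compound 3 the estimated clearance is 220 mL/min/kg, with an expected range of 80 mL/min/kg to 550 mL/min/kg.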

Compound 3, clearance: 98.5 mL/min/kg
Beside the measured number, compound 3's estimate is 2.2-fold (0.35 log units) above it; low and high end bracket the measured number.
By their numbers in this assay, from the lowest: compounds 1 and 3 (each within the scatter of the next); then compound 2.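

In this assay, dimethylamino in place of ethyl on an aromatic carbon, para to a large group, gives a 2.9-fold lower number from compound 2 to compound 3 (0.47 log units; beyond the scatter) and so shows that this position also bears on the clearance reading. The earlier step, a 5.2-fold higher number from compound 1 to compound 2 (0.71 log units; beyond the scatter), came from the saturated chain carbon bound to the sulfonamide nitrogen, so two separate places on the molecule have now each moved the number beyond the scatter, and the new change moves it toward slower removal. Nothing measured here explains why dimethylamino goes with a lower number than ethyl at this position.

On these data alone, what a methoxy group, a primary amine or a chlorine atom would give on the same aromatic carbon stays open, so the lower number cannot yet be tied to dimethylamino in particular or to replacing ethyl in general. Also open, as far as these compounds go, is whether the same exchange would lower the number when cyclopropyl, as in compound 1, stands on the chain carbon in place of the isopropyl shared by compound 2 and compound 3.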